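A few compounds are considered here, and "the series" means these few. Any claim that something is new, unique, unknown or untested is made for them only; others in the source may bear on it.

In an assay on isolated protein for inhibition of cathepsin S (Homo sapiens) (on this read-out lower numbers stand for stronger inhibition and higher numbers for weaker inhibition), compound 1, with the structure `N#C[C@@]1(NC(=O)[C@@H](CC(=O)N2CCOCC2)CC2CCC(c3ccccc3)CC2)CCN(C2CCCCC2)C1`, gives 3140 nM, the higher of the two numbers recorded so far. Compound 2, `N#C[C@H](COCc1ccccc1)NC(=O)[C@@H](CC(=O)N1CCOCC1)CC1CCCCC1`, is built on a different core and gives 37 nM in this assay, a far lower number. The two compounds differ in many places at once. This gap says nothing about any single group. Compound 3, `N#C[C@@]1(NC(=O)[C@@H](CC(=O)N2CCOCC2)CC2Cc3ccccc3C2)CCN(C2CCCCC2)C1`, keeps the core of compound 1 and changes one group: 2,3-dihydro-1H-inden-2-yl in place of 4-phenylcyclohexyl on a saturated chain carbon, two bonds along the chain from a carbonyl carbon. Within the data shown here, no measured pair tracks this exact exchange, so the size of its effect is open. The expectation for compound 3 is a step of a 1.6-fold lower number from compound 1 to compound 3 (0.20 log units; within the scatter), a shift that stays within or near the scatter of repeated runs. Compound 3 is therefore estimated at 2000 nM in this assay, with a plausible range from 500 nM to 8000 nM.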

Compound 3, half-maximal inhibitory concentration: 42 nM
The estimate for compound 3 lay 48-fold (1.68 log units) above the measured number, outside the stated range (below it).
By their numbers in this assay, from the lowest: compounds 2 and 3 (each within the scatter of the next); then compound 1.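

In this assay, the group on a saturated chain carbon, two bonds along the chain from a carbonyl carbon, proves to matter greatly: 2,3-dihydro-1H-inden-2-yl in place of 4-phenylcyclohexyl brings a 75-fold lower number from compound 1 to compound 3 (1.87 log units; beyond the scatter). Among these compounds, compound 1 and compound 2 could not show this, since they differ in many places at once, whereas here the core of compound 1 stays and only this all-carbon group changes, with no hydrogen-bond donors, hydrogen-bond acceptors or net charge on either side. No measurement shown explains the size of this step.

The two groups differ in both carbon count and non-aromatic ring size, so the compounds shown cannot separate these two changes. On these data alone, it also remains open how a cyclopentyl or naphthyl group would read out at this place, and whether the same exchange would give a similar step on another core.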